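The compounds below may be only part of what the source reports. "The series", "measured", "known", "first", "only" and "open" are said of these compounds alone.

- Compound 1 `C/C(=N\NC(=O)/C(C#N)=C/c1ccccc1)c1c(O)c2ccc(O)cc2oc1=O`: 19200 nM
- Compound 2 `COc1cc(/C=C(\C#N)C(=O)N/N=C(\C)c2c(O)c3ccc(O)cc3oc2=O)ccc1O`: 13700 nM
- Compound 3 `COc1cc(/C=C(\C#N)C(=O)N/N=C(\C)c2c(O)c3ccc(O)cc3oc2=O)cc(OC)c1OC`: 11300 nM

These three compounds share one core and differ only in the group on a double-bonded chain carbon bound to a double-bonded chain carbon. In a functional assay on MCF7 cells (Homo sapiens) for cytotoxicity, read by MTT assay, with a stated time of 24 h (a higher number here means a weaker inhibitor, a lower number a stronger inhibitor), compound 2 gives 13700 nM, and this number stands amid the three, within the scatter of both compound 1 and compound 3.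

Compound 4 `C/C(=N\NC(=O)/C(C#N)=C/c1ccc(Br)cc1)c1c(O)c2ccc(O)cc2oc1=O` has not yet been measured. It differs from compound 2 in one place: 4-bromophenyl in place of 4-hydroxy-3-methoxyphenyl on a double-bonded chain carbon bound to a double-bonded chain carbon. The new group, 4-bromophenyl, sits on the same double-bonded chain carbon bound to a double-bonded chain carbon.

Going by the values given here, one measured step bears directly on this place, a 1.4-fold lower number from compound 1 to compound 2 (0.15 log units; within the scatter), and it stays within the scatter. Compound 3, with yet another group there, gives 11300 nM, which is also within the scatter of compound 2. Among the compounds with values here, no measured compound carries bromine, so the data offer no direct reading of this particular group. With a 1.4-fold lower number from compound 1 to compound 2 (0.15 log units; within the scatter) as the guide, no shift beyond the scatter is expected in this assay, and no direction is favoured.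

The estimated change is a 1.1-fold lower number from compound 2 to compound 4 (0.06 log units; within the scatter). For compound 4 the expected value is 12000 nM, with an estimated range from 6000 nM to 24000 nM.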

Compound 4, half-maximal inhibitory concentration: 9850 nM
The estimate for compound 4 lay 1.2-fold (0.09 log units) above the measured number; measured number inside the range.
By their numbers in this assay, from the lowest: compounds 4, 3, 2 and 1 (each within the scatter of the next).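

In this assay, the place on a double-bonded chain carbon bound to a double-bonded chain carbon also tolerates 4-bromophenyl in place of 4-hydroxy-3-methoxyphenyl, with a 1.4-fold lower number from compound 2 to compound 4 (0.14 log units; within the scatter) as the result, so a group with 0 hydrogen-bond donors and 0 hydrogen-bond acceptors, and with bromine as a new atom, leaves the number within the scatter of the group carrying 1 donor and 2 acceptors. Setting bromo in place of hydrogen on an aromatic carbon gives a 1.9-fold lower number from compound 1 to compound 4 (0.29 log units; within the scatter) and so also stays within the scatter, which means that all the single changes read so far at this place, whether they add oxygen groups or a bromine, fail to move the number beyond it. No measurement on hand says why these steps are this small.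

Every group shown at this place is a six-membered aromatic ring of carbon only, so it remains open whether a longer alkyl chain, or a ring carrying an amine or a carboxylic acid, would leave the number within the scatter. As far as these compounds go, it is equally open whether fluoro or chloro in place of bromo would behave as bromo does in this assay or would shift the number beyond the scatter.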